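Methoxy to hydroxy on the aryl ring of compound 3

This account rests on a few compounds, and the source may have more. Where it says the series, first, only, none or still open, it means among the compounds named here.

Measured so far:
compound 1 `O=C(Nc1cccc(-n2cc(-c3ccncc3)c(-c3ccc(Cl)c(O)c3)n2)c1)Nc1cccc(C(F)(F)F)c1` — > 32500 nM
compound 2 `COc1cc(-c2nn(-c3cccc(NC(=O)c4cccc(C(F)(F)F)c4)c3)cc2-c2ccncc2)ccc1Cl` — > 50000 nM
compound 3 `COc1cc(-c2nn(-c3cccc(NC(=O)Nc4ccc(Cl)c(Cl)c4)c3)cc2-c2ccncc2)ccc1Cl` — > 50000 nM

All three values in a functional assay on DU-145 cells (Homo sapiens) for inhibition, read by sulforhodamine B assay, with a stated time of 48 h (a higher number here means that more compound is tolerated, a lower number that less compound is tolerated), are limits of the assay rather than numbers. Compound 1 reaches only the limit (the limit of > 32500 nM in this assay, at which 1 of the 3 values shown sits). Compound 2 and compound 3 each sit at the limit (the limit of > 50000 nM in this assay, at which 2 of the 3 values shown sit). Among the measured compounds shown here, the single measured step, a step that the two limits leave unreadable from compound 2 to compound 3, is therefore unreadable in size and direction. For the measured compounds named here, compound 3 thus stands at a limit, with no measured step that resolves anything.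

Compound 4 `O=C(Nc1cccc(-n2cc(-c3ccncc3)c(-c3ccc(Cl)c(O)c3)n2)c1)Nc1ccc(Cl)c(Cl)c1` differs from compound 3 by hydrogen in place of methyl on an oxygen on an aromatic ring. The same methoxy-to-hydroxy contrast separates compound 2 from compound 1, though those two also differ elsewhere, and both of those values are limits as well. Going by the values given here, no measured step bears on the change from compound 3 to compound 4 with a readable size. With every value in this assay sitting at a limit, the expectation is that compound 4 will likewise show no measurable effect, and the step of a number no higher from compound 3 to compound 4 (the limit leaves the size open) is estimated as none beyond the scatter. Compound 4 is expected to give 50000 nM, with a range from 20000 nM to 150000 nM, most probably reported again as a limit.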

Compound 4, concentration lethal to 50% of the cells: > 32500 nM
Compound 4 gave a limit, no number (the forecaster's own chance of this, stated with the estimate: 80%); the middle value does not contradict the limit.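

In this assay compound 4 gives > 32500 nM, a limit of the assay. Compound 3 gives > 50000 nM, also a limit. Compound 1 gives > 32500 nM, again a limit. Among the compounds shown here, no step can therefore be read from compound 3 to compound 4 or from compound 1 to compound 4. The compounds shown leave open whether methoxy to hydroxy, or either aryl group on the urea, changes the read-out in this assay at all.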